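The compounds below may be only part of what the source reports. "The series", "measured", "known", "first", "only" and "open" are said of these compounds alone.

Measured in a functional assay on CAL-51 cells (Homo sapiens) for inhibition, read by sulforhodamine B assay, with a stated time of 3 days; on this read-out lower numbers stand for stronger inhibition of growth and higher numbers for weaker inhibition of growth:
Compound 1 `Cc1ccc(COc2ccc(C(=O)/C=C/c3ccc(Cl)cc3)cc2)cc1` gives > 50000 nM, a limit of the assay.
Compound 2 `O=C(/C=C/c1ccc(Cl)cc1)c1ccccc1` gives 5850 nM.
Compound 3 `O=C(/C=C/c1ccc(F)cc1)c1ccc(OCc2ccccc2)cc1` gives > 50000 nM, again a limit of the assay.

So compound 3 has no number in this assay, only a limit, and one further value shown is a limit as well, as the limit of > 50000 nM in this assay, at which 2 of the 3 values shown sit, records. Only compound 2 gives a measured number. Compound 4 `O=C(/C=C/c1ccc(Cl)cc1)c1ccc(OCc2ccccc2)cc1` differs from compound 3 by chloro in place of fluoro on an aromatic carbon. Among the measured compounds shown here, no measured pair shows this change on its own. Compound 1, which also carries chloro, stands at the limit. Compound 4 is therefore expected to give 60000 nM, in a range from 15000 nM to 200000 nM, most likely again reported only as a limit. The expected step that the limit leaves unreadable from compound 3 to compound 4 is none beyond the scatter.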

Compound 4, concentration for 50% growth inhibition: > 50000 nM
Compound 4 ended at the assay's limit; the forecaster's own chance of this, stated with the estimate: 75%; the middle value lies beyond the limit too.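

In this assay, benzyloxy in place of hydrogen on an aromatic carbon gives an at least 8.5-fold higher number from compound 2 to compound 4 (0.93 log units; beyond the scatter), which shows that this group costs growth inhibition with the 4-chlorophenyl kept. The steps to compound 4 from compound 3 and from compound 1 cannot be read, and the size of any effect of chloro in place of fluoro stays hidden: the limit of > 50000 nM in this assay, at which 3 of the 4 values shown sit.

From the compounds shown here alone, it remains open whether methoxy or hydroxy in place of benzyloxy would return a measured number. Going by these compounds, it also remains open whether fluoro in place of chloro would change the value of compound 2.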